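The compounds below may be only part of what the source reports. "The series", "measured", "known", "first", "only" and "open" are said of these compounds alone.

In a functional assay on MOLT-4 cells (Homo sapiens) (on this read-out lower numbers stand for stronger inhibition and higher numbers for weaker inhibition), compound 1 `Nc1ncnc2c1ncn2C[C@@H]1C[C@H](CO)c2ccccc21` gives 24 ug/mL. Going by the values given here, compound 3 `COc1ncnc2c1ncn2C[C@@H]1C[C@H](CO)c2ccccc21` gives 24 ug/mL, the same figure, and these two share the highest number of the three measured so far. Compound 2 `Cc1ccc(-c2ncnc3c2ncn3C[C@@H]2C[C@H](CO)c3ccccc32)cc1` stands well apart at 1.4 ug/mL.

Still unmeasured is compound 4 `CC(C)Nc1ncnc2c1ncn2C[C@@H]1C[C@H](CO)c2ccccc21`, which keeps the core of compound 1 and differs in one place: isopropyl in place of hydrogen on a nitrogen on an aromatic ring. Here isopropyl stands in place of hydrogen on a nitrogen on an aromatic ring, so amino becomes isopropylamino.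

Two measured steps act at this same place, although both replace the whole amino group rather than adding to it. Methoxy in place of amino gives no change at the digits printed from compound 1 to compound 3 (within the scatter). By contrast, 4-methylphenyl in place of amino gives a 17-fold lower number from compound 1 to compound 2 (1.23 log units; beyond the scatter), a large step. Among the compounds with values here, no measured compound carries an added group on that nitrogen, so this evidence is indirect. The two steps suggest that a change here can leave the number alone or lower it, and isopropyl has no ring, unlike 4-methylphenyl. Only a modest move towards a lower number is therefore expected, and the expected step is a 1.7-fold lower number from compound 1 to compound 4 (0.23 log units; within the scatter). Compound 4 is estimated at 14 ug/mL, with an expected range from 4 ug/mL to 40 ug/mL.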

Compound 4, half-maximal inhibitory concentration: 24 ug/mL
Estimate against measurement, compound 4: 1.7-fold (0.23 log units) below, within the range that was stated.
By their numbers in this assay, from the lowest: compound 2; then compounds 1, 3 and 4 (each within the scatter of the next).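

In this assay, going by these compounds alone, isopropyl on the nitrogen of the amino group gives no change at the digits printed from compound 1 to compound 4 (within the scatter), the first direct reading of adding to that nitrogen rather than replacing the whole amino group, and here the addition leaves the number unmoved. Isopropylamino in place of methoxy on the same aromatic carbon gives no change at the digits printed from compound 3 to compound 4 (within the scatter), while isopropylamino in place of 4-methylphenyl gives a 17-fold higher number from compound 2 to compound 4 (1.23 log units; beyond the scatter), so among these four compounds only compound 2, the one with a ring at this position, stands apart from the rest. No measurement here accounts for this pattern.

The compounds shown leave open whether a ring attached through the nitrogen, as in a benzylamino or anilino group, would reach the lower number of compound 2, or whether that ring must sit directly on the aromatic carbon. They also leave open how much the methyl of the 4-methylphenyl group contributes, which a plain phenyl group at this position would test, and whether a longer chain on the nitrogen, such as hexyl, would behave like isopropyl.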